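A few compounds are considered here, and "the series" means these few. Any claim that something is new, unique, unknown or untested is made for them only; others in the source may bear on it.

Measured so far in an ADME assay on liver (Mesocricetus auratus) for metabolic stability, using microsomes; a lower number here means slower removal, a higher number faster removal of the compound:
- compound 1 `O=C(Nc1[nH]nc(-c2ccccn2)c1C1CC1)c1ccccc1F`: > 100 mL.min-1.g-1
- compound 2 `N#Cc1ccc(C2CCN(C(=O)Nc3cc(-c4ccccn4)n[nH]3)CC2)cc1`: 80.8 mL.min-1.g-1
- compound 3 `O=C(Nc1cc(-c2ccccn2)n[nH]1)N1CCC(c2ccc(F)cc2)CC1`: 272 mL.min-1.g-1

Compound 1 has only a limit in this assay, not a number: the limit of > 100 mL.min-1.g-1 in this assay, at which 1 of the 3 values shown sits. Compound 4 `COc1ccccc1C(=O)Nc1[nH]nc(-c2ccccn2)c1C1CC1` keeps the core of compound 1 and differs from it by methoxy in place of fluoro on an aromatic carbon. This is methoxy in place of fluoro on an aromatic carbon, ortho to a large group.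

Among the compounds with values here, only one measured step bears on this change, and only loosely: a 3.4-fold higher number from compound 2 to compound 3 (0.53 log units; beyond the scatter). Within the data shown here, there fluoro replaces cyano, on compounds built differently from compound 1, and no measured step brings in methoxy. That modest step gives a rough size for a single exchange on an aromatic carbon, but it does not fix a direction here. No step beyond the scatter is therefore expected in this assay, and fast removal is expected to persist. The estimated change is a step that the limit leaves unreadable from compound 1 to compound 4. Compound 4 is expected at 130 mL.min-1.g-1, with an estimated range of 50 mL.min-1.g-1 to 350 mL.min-1.g-1.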

Compound 4, intrinsic clearance in microsomes: > 100 mL.min-1.g-1
Compound 4: a limit, no number (the forecaster's own chance of this, stated with the estimate: 35%); the middle value is on the limit's open side.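

In this assay, compound 1 and compound 4 both give a limit rather than a number, so no step between them can be read: the limit of > 100 mL.min-1.g-1 in this assay, at which 2 of the 4 values shown sit.

The compounds shown leave open how fast either compound is removed, and whether 2-methoxyphenyl differs at all from 2-fluorophenyl on the core of compound 1.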